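What a 3-chlorophenyl group may do to growth inhibition

The source may report more compounds than this note shows. Statements on the series, on what has been measured and on what is new or still open speak of the compounds shown alone.

Measured so far in a functional assay on COLO 205 cells (Homo sapiens) for inhibition, read by sulforhodamine B assay; on this read-out higher numbers stand for weaker inhibition of growth and lower numbers for stronger inhibition of growth:
- compound 1 `Oc1cccc2[nH]c(-c3ccc(-c4ccc(-c5ccc(OC(F)(F)F)cc5)cc4)cc3)nc12` gives 8320 nM
- compound 2 `CN(C)c1ccc(-c2ccc(-c3ccc(-c4nc5c(O)cccc5[nH]4)cc3)cc2)cc1` gives 6320 nM

Compound 2 stands level with compound 1 on these numbers. The two differ only within the scatter, as a 1.3-fold lower number from compound 1 to compound 2 (0.12 log units; within the scatter) shows for dimethylamino in place of trifluoromethoxy on an aromatic carbon.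

Compound 3 `Oc1cccc2[nH]c(-c3ccc(-c4ccc(-c5cccc(Cl)c5)cc4)cc3)nc12` has not yet been measured. It differs from compound 2 by 3-chlorophenyl in place of 4-(dimethylamino)phenyl on an aromatic carbon, para to a large group (3-chlorophenyl in place of 4-(dimethylamino)phenyl on an aromatic carbon). Within the data shown here, only one measured step bears on this change, and it is thin evidence, since no measured compound carries 3-chlorophenyl. Taking a 1.3-fold lower number from compound 1 to compound 2 (0.12 log units; within the scatter) as the only guide, no step beyond the scatter is expected in this assay and neither direction can be favoured. The expected outcome is a 1.1-fold higher number from compound 2 to compound 3 (0.04 log units; within the scatter) for this change. For compound 3 the estimated value is 7000 nM (range 3000 nM to 16000 nM).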

Compound 3, concentration for 50% growth inhibition: 8600 nM
For compound 3 the middle estimate is 1.2-fold (0.09 log units) below the measured one; measured number inside the range.
By their numbers in this assay, from the lowest: compounds 2, 1 and 3 (each within the scatter of the next).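

In this assay, a third end group at this position, on an aromatic carbon para to a large group, leaves the number level with both earlier compounds (a 1.4-fold higher number from compound 2 to compound 3 (0.13 log units; within the scatter)) (a 1.0-fold higher number from compound 1 to compound 3 (0.01 log units; within the scatter)). Among these compounds, the earlier pair showed only that two groups at the 4-position of the end ring gave matching numbers, whereas 3-chlorophenyl carries its substituent at a different ring position, has fewer heavy atoms than 4-(dimethylamino)phenyl, and has no hydrogen-bond acceptor where that group has one. Across these three compounds, none of those differences separates the numbers beyond the scatter, and no compound shown goes against this flat picture. No supporting evidence is available to explain this result.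

As far as these compounds go, all three compounds carry a substituted phenyl ring at this position, so it remains open whether a group of another kind, such as a carboxylic acid, a morpholine ring or a longer chain ending in an amine, would move the number beyond the scatter. From the compounds shown here alone, it is also open whether the same flat picture would hold on a core altered elsewhere, for example with the hydroxyl group replaced by a methoxy group.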